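The compounds below may be only part of what the source reports. "The series", "measured", "known", "first", "only" and "open" are said of these compounds alone.

Of the compounds shown here, three sharing one core have been measured in a functional assay on SW 1116 cells (Homo sapiens) for antiproliferative activity, read by MTT assay, with a stated time of 48 h; a lower number here means that less compound is needed, a higher number that more compound is needed for the effect. Compound 1 `O=C(CCc1ccccc1)Nc1nnc(-c2ccc3c(c2)OCCO3)s1` gives 16.2 ug/mL and compound 2 `Nc1ccc(C(=O)Nc2nnc(-c3ccc4c(c3)OCCO4)s2)cc1` gives 41.2 ug/mL, while compound 3 `O=C(/C=C/c1ccccc1)Nc1nnc(-c2ccc3c(c2)OCCO3)s1` gives 60.2 ug/mL; where compound 3 stands is told by a 3.7-fold higher number from compound 1 to compound 3 (0.57 log units; beyond the scatter) and by a 1.5-fold higher number from compound 2 to compound 3 (0.16 log units; within the scatter). Compound 4 `O=C(Nc1nnc(-c2ccc3c(c2)OCCO3)s1)c1ccncc1` differs from compound 3 in one place only: pyridin-4-yl in place of 2-phenylethenyl on a carbonyl carbon. Every measured step is likewise a swap of the group on that carbonyl carbon. Exchanging one six-membered aromatic ring for another most resembles the step between compound 2 and compound 3, which stayed within the scatter, whereas the step from compound 1, with its phenethyl group, was larger. For compound 4 a small lowering is therefore expected, a 1.5-fold lower number from compound 3 to compound 4 (0.18 log units; within the scatter), giving an estimate of 40 ug/mL with a range from 15 ug/mL to 100 ug/mL.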

Compound 4, half-maximal effective concentration: > 100 ug/mL
Compound 4: no number, only a limit; the forecaster's own chance of this, stated with the estimate: 10%; middle value at least 2.5-fold (0.39 log units) away from the limit.
By their numbers in this assay, from the lowest: compound 1; then compounds 2 and 3 (each within the scatter of the next). At a limit, above all of these: compound 4.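

In this assay compound 4 gives no number, only a limit of the assay: the limit of > 100 ug/mL in this assay, at which 1 of the 4 values shown sits. Exchanging one six-membered aromatic ring for another on this carbonyl carbon is not a neutral swap, as shown by an at least 2.4-fold higher number from compound 2 to compound 4 (0.38 log units; beyond the scatter); the pyridin-4-yl group also stands apart from phenethyl, with an at least 6.1-fold higher number from compound 1 to compound 4 (0.79 log units; beyond the scatter). The remaining step, an at least 1.6-fold higher number from compound 3 to compound 4 (0.22 log units; that floor lies within the scatter), settles less, as its floor lies within the scatter.

A plain phenyl group on that carbonyl carbon would help separate the role of the ring nitrogen from that of the amine in compound 2. Going by these compounds, how far compound 4 lies past its limit stays open.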